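This account rests on a few compounds, and the source may have more. Where it says the series, first, only, none or still open, it means among the compounds named here.

Three compounds have been measured in a functional assay on NCI-H460 cells (Homo sapiens) for antiproliferative activity, read by CCK-8 assay, with a stated time of 72 h, tested at 2 uM; a higher number here means a stronger effect of the compound at the concentration tested, a lower number a weaker effect:

Compound 1 `Nc1ccccc1NC(=O)/C=C/c1ccc(COCNc2nc(Nc3cccc(Cl)c3)c3ncn(C4CCCC4)c3n2)cc1`: 37.1%
Compound 2 `Nc1ccccc1NC(=O)c1ccc(COCNc2nc(Nc3ccccc3)c3ncn(C4CCCC4)c3n2)cc1`: 41.2%
Compound 3 `CCCCn1cnc2c(Nc3cccc(Cl)c3)nc(NCOCc3ccc(C(=O)Nc4ccccc4N)cc3)nc21`: 56.9%

Compound 3 stands highest of the three in this assay; its nearest neighbour is compound 2, and the gap to it, like the larger gap to compound 1, lies beyond the usual scatter. Compound 4 `Nc1ccccc1NC(=O)c1ccc(COCNc2nc(Nc3cccc(Cl)c3)c3ncn(C4CCCC4)c3n2)cc1` differs from compound 3 in one place: cyclopentyl in place of butyl on an aromatic nitrogen. Among the measured compounds shown here, no pair of measured compounds shows this step, so its size is not known from direct comparison. Since compound 2 already carries the cyclopentyl and gives 41.2%, a modest drop from compound 3 is expected, probably not beyond the scatter. Compound 4 is therefore estimated at 48%, within 35% to 62%, a step of a number 8.9 percentage points lower from compound 3 to compound 4 (within the scatter).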

Compound 4, a percentage reported as inhibition, at one concentration (the size of the read-out at that concentration, not a potency): 36.1%
Compound 4: middle estimate off by 11.9 percentage points, on the high side, and the stated range covers the measured number.
By their numbers in this assay, from the lowest: compounds 4, 1 and 2 (each within the scatter of the next); then compound 3.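

On the aromatic nitrogen of the shared core, butyl and cyclopentyl are not interchangeable in this assay (a number 20.8 percentage points lower from compound 3 to compound 4 (beyond the scatter)), so this position is sensitive to which carbon group it carries. Two other changes stay inside the scatter: chloro in place of hydrogen on an aromatic carbon (a number 5.1 percentage points lower from compound 2 to compound 4 (within the scatter)) and (2-aminophenyl)carbamoyl in place of 2-((2-aminophenyl)carbamoyl)ethenyl (a number 1 percentage points lower from compound 1 to compound 4 (within the scatter)). No available evidence explains the difference between butyl and cyclopentyl. On these data alone, whether methyl, a longer chain such as hexyl, or a butyl chain ending in an amine would hold or raise the effect at this nitrogen remains open.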